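Moving the pyridine nitrogen in a chalcone-like series

A few compounds are considered here, and "the series" means these few. Any claim that something is new, unique, unknown or untested is made for them only; others in the source may bear on it.

Measured compounds:
Compound 1, `CSc1ccc(C(=O)/C(=C/c2cc3ccccc3s2)c2ccc(Cl)c(Cl)c2)cc1`: 91.6%
Compound 2, `CSc1ccc(C(=O)/C(=C/c2cccnc2)c2ccc(Cl)c(Cl)c2)cc1`: 89.6%

In an ADME assay on Vero cells (Chlorocebus sabaeus) for cytotoxicity, read by MTT assay, tested at 50 uM (a lower number here means a stronger effect, a higher number a weaker effect of the compound at the concentration tested), compound 1 gives 91.6% and compound 2 gives 89.6%. Among the compounds with values here, the one step between them, a number 2 percentage points lower from compound 1 to compound 2 (within the scatter), lies within the scatter, so compound 2 stands together with compound 1 in this assay, the two numbers indistinguishable.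

Compound 3, `CSc1ccc(C(=O)/C(=C/c2ccccn2)c2ccc(Cl)c(Cl)c2)cc1`, has not yet been measured. It differs from compound 2 by pyridin-2-yl in place of pyridin-3-yl on a double-bonded chain carbon bound to a double-bonded chain carbon.

Within the data shown here, only one measured step bears on this change, and only loosely: the exchange of the 1-benzothiophen-2-yl group for pyridin-3-yl at the same place, a number 2 percentage points lower from compound 1 to compound 2 (within the scatter), did not move the read-out beyond the scatter. The shift from pyridin-3-yl to pyridin-2-yl is a smaller alteration than that one. Compound 3 is therefore expected to show no step beyond the scatter in this assay, so that a number 0.4 percentage points higher from compound 2 to compound 3 (within the scatter) is estimated to be small. Compound 3 is expected to give about 90%, with a range from 78% to 99%.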

Compound 3, a percentage reported as activity, at one concentration (the size of the read-out at that concentration, not a potency): 93.6%
Estimate against measurement, compound 3: 3.6 percentage points below, and the stated range covers the measured number.
By their numbers in this assay, from the lowest: compounds 2, 1 and 3 (each within the scatter of the next).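

In this assay, moving the ring attachment from pyridin-3-yl to pyridin-2-yl on a double-bonded chain carbon bound to a double-bonded chain carbon gives a number 4 percentage points higher from compound 2 to compound 3 (within the scatter), so this rearrangement of the same atoms leaves the read-out within the scatter. The exchange of 1-benzothiophen-2-yl for pyridin-2-yl at the same place gives a number 2 percentage points higher from compound 1 to compound 3 (within the scatter), which means that two different pyridine attachments now each stand level with the benzothiophene compound, and the three compounds cannot be told apart in this read-out. Nothing available here speaks to what lies behind these results.

The compounds shown leave open whether a pyridin-4-yl group, a carboxylic acid or an aliphatic amine at this place would also stay within the scatter of these three compounds. They also leave open whether a change elsewhere on the shared core, such as replacing the methylthio group with a longer alkyl chain, would move the read-out, as all three compounds carry that part unchanged.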